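Hydroxyphenyl positional swap and solubility

A few compounds are considered here, and "the series" means these few. Any claim that something is new, unique, unknown or untested is made for them only; others in the source may bear on it.

Compound 1 `O=C(/C=C/c1cccc(O)c1)/C=C/c1ccc(O)c(O)c1` and compound 2 `O=C(/C=C/c1ccc(O)cc1)/C=C/c1ccc(O)c(O)c1` share one core; compound 3 `O=C(/C=C/c1cccc(O)c1)/C=C/c1cccc(O)c1O` and compound 4 `O=C(/C=C/c1ccc(O)cc1)/C=C/c1cccc(O)c1O` share another, and the difference between the two cores is not broken down here. In a physicochemical assay for solubility, using the shake flask method, with a stated time of 12 h (on this read-out higher numbers stand for higher solubility and lower numbers for lower solubility), compound 1 gives 60000 nM, while compound 2 gives 19000 nM. The change from compound 1 to compound 2 is 4-hydroxyphenyl in place of 3-hydroxyphenyl on a double-bonded chain carbon bound to a double-bonded chain carbon, and it produced a 3.2-fold lower number from compound 1 to compound 2 (0.50 log units; beyond the scatter). In this assay compound 3 gives 184000 nM, the highest of the three measured values. Compound 4 is related to compound 3 by 4-hydroxyphenyl in place of 3-hydroxyphenyl on a double-bonded chain carbon bound to a double-bonded chain carbon, the same change at the same place. For the measured compounds named here, a step of the same size is expected in this assay, a 3.2-fold lower number from compound 3 to compound 4 (0.50 log units; beyond the scatter), resting on the single measured instance, a 3.2-fold lower number from compound 1 to compound 2 (0.50 log units; beyond the scatter). Compound 4 is accordingly estimated at 58000 nM, with an expected range from 25000 nM to 130000 nM.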

Compound 4, solubility: 120000 nM
Compound 4: middle estimate off by 2.1-fold (0.32 log units), on the low side; the range from low to high includes it.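

In this assay the change of 3-hydroxyphenyl to 4-hydroxyphenyl gives a 1.5-fold lower number from compound 3 to compound 4 (0.19 log units; within the scatter), a step within the scatter and so not distinguishable from no change, whereas on the other core it gives a 3.2-fold lower number from compound 1 to compound 2 (0.50 log units; beyond the scatter), which lies beyond the scatter. The change therefore did not carry over as a clear step to the core of compound 3, but two pairs cannot show how far the effect of this change depends on the core in general. Nothing available bears on what lies behind the difference between the two steps.

From the compounds shown here alone, whether either step holds on a further core remains open. So does the result in this assay of an amine or a carboxylic acid in place of the hydroxyl group.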